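Predicting a Fluorine Swap in Compound 4

The source may hold more compounds than are shown below. What is called first, only, known or untested is meant among the compounds shown, and "the series" means these compounds.

Three compounds have been measured in a functional assay on A549 cells (Homo sapiens) for antiproliferative activity, read by MTT assay, with a stated time of 48 h; on this read-out higher numbers stand for weaker inhibition and lower numbers for stronger inhibition:

compound 1, `COc1ccc(-c2nnc(NC(=O)/C=C/c3ccc(F)cc3)s2)cc1`: 0.75 ug/mL
compound 2, `Cc1ccc(-c2nnc(NC(=O)/C=C/c3ccccc3)s2)cc1`: 1.38 ug/mL
compound 3, `COc1ccc(-c2nnc(NC(=O)/C=C/c3ccccc3)s2)cc1`: 0.68 ug/mL

Compound 4, `Cc1ccc(-c2nnc(NC(=O)/C=C/c3ccc(F)cc3)s2)cc1`, has not yet been measured. It differs from compound 2 by one change, (fluoro in place of hydrogen on an aromatic carbon). That change has already been made once among the measured compounds: compound 1 differs from compound 3 by fluoro in place of hydrogen on an aromatic carbon, and the outcome was a 1.1-fold higher number from compound 3 to compound 1 (0.04 log units; within the scatter). The place of the change reads the same word for word in both pairs, so this is the same change, only set on a different core.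

The two cores differ in one spot: compound 2 differs from compound 3 by methyl in place of methoxy on an aromatic carbon, and that difference gave a 2.0-fold lower number from compound 2 to compound 3 (0.31 log units; beyond the scatter). Compound 2 has the highest number of the three, but its gap to compound 1 lies within the scatter, so no order between those two can be read from the data.

The expectation for compound 4 rests on the fluorine step already seen: because a 1.1-fold higher number from compound 3 to compound 1 (0.04 log units; within the scatter) stayed within the scatter, the same change on the core of compound 2 is expected to move the number little. On that basis compound 4 is expected to show a 1.1-fold higher number from compound 2 to compound 4 (0.02 log units; within the scatter). In this assay compound 4 is therefore estimated at 1.45 ug/mL, most likely between 0.8 ug/mL and 2.6 ug/mL.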

Compound 4, half-maximal inhibitory concentration: 1.23 ug/mL
Beside the measured number, compound 4's estimate is 1.2-fold (0.07 log units) above it; measured number inside the range.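

In this assay, the change from phenyl to 4-fluorophenyl gave a 1.1-fold lower number from compound 2 to compound 4 (0.05 log units; within the scatter), so on the core of compound 2 it again left no readable mark on the number, just as it did on the core of compound 3: the same change on two cores in this assay, a 1.1-fold higher number (0.04 log units; within the scatter) from compound 3 to compound 1 and a 1.1-fold lower number (0.05 log units; within the scatter) from compound 2 to compound 4, 1.2-fold (0.09 log units) apart, within the scatter of two such steps. The other new step, with methyl in place of methoxy on the fluorinated core, is a 1.6-fold higher number from compound 1 to compound 4 (0.21 log units; within the scatter); this alone lies within the scatter, while the same change without fluorine went just beyond it, yet the two steps cannot be told apart: the same change on two cores in this assay, a 2.0-fold lower number (0.31 log units; beyond the scatter) from compound 2 to compound 3 and a 1.6-fold lower number (0.21 log units; within the scatter) from compound 4 to compound 1, 1.2-fold (0.09 log units) apart, within the scatter of two such steps. Together these steps show that, on these two closely related cores, the fluoro group can be carried across with no visible difference in outcome, but they do not show that the fluoro group has no effect at all, since a small real shift could hide within the scatter, nor that the same would hold on any further core.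

From the compounds shown here alone, how a chloro group, a nitrile or an amine in that same place would move the number remains open. So does whether a hydroxyl group or a longer chain in place of the methyl or methoxy would keep the number as low as the methoxy compounds do.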